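Para-fluoro on the benzamide of a cytosine butenyl analogue

A few compounds are considered here, and "the series" means these few. Any claim that something is new, unique, unknown or untested is made for them only; others in the source may bear on it.

Compound 1 `Cc1cn(C/C=C\CNC(=O)c2ccccc2)c(=O)[nH]c1=O`, compound 2 `Nc1ccn(C/C=C\CNC(=O)c2ccccc2)c(=O)n1` and compound 3 `Cc1cn(C/C=C\CNC(=O)c2ccc(F)cc2)c(=O)[nH]c1=O` have been measured.

In a functional assay on MIA PaCa-2 cells (Homo sapiens) for cytotoxicity, read by MTT assay, with a stated time of 72 h (on this read-out higher numbers stand for weaker inhibition and lower numbers for stronger inhibition), compound 1 gives only a limit, > 100000 nM. Compound 2 likewise gives only a limit in this assay, > 100000 nM. Compound 3 too sits at a limit, > 100000 nM. The difference between the cores of compound 1 and compound 2 is not broken down here. Compound 3 arises from compound 1 by fluoro in place of hydrogen on an aromatic carbon, and the step that the two limits leave unreadable from compound 1 to compound 3 cannot be read because of the limit of > 100000 nM in this assay, at which 3 of the 3 values shown sit.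

Compound 4 `Nc1ccn(C/C=C\CNC(=O)c2ccc(F)cc2)c(=O)n1` has not been measured; it arises from compound 2 by fluoro in place of hydrogen on an aromatic carbon, the same change. Because (the limit of > 100000 nM in this assay, at which 3 of the 3 values shown sit), the step that the limit leaves unreadable from compound 2 to compound 4 is expected to be small or unreadable. Compound 4 is therefore estimated at 150000 nM, with a range of 70000 nM to 500000 nM, and most likely only a limit will be reported.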

Compound 4, half-maximal inhibitory concentration: > 100000 nM
Compound 4: a limit, no number; the forecaster's own chance of this, stated with the estimate: 90%; the middle value does not contradict the limit.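

No step can be read from compound 2 to compound 4, since both values are limits: the limit of > 100000 nM in this assay, at which 4 of the 4 values shown sit.

The compounds shown leave open whether phenyl to 4-fluorophenyl, or the difference between the cores, changes the result at all in this assay.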